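The source may report more compounds than this note shows. Statements on the series, on what has been measured and on what is new or still open speak of the compounds shown alone.

Compound 3 `Cc1c(C(=O)N/N=C\c2ccccc2)oc2cccc(O)c12` carries a plain phenyl on the carbon with a double bond to nitrogen. Among the compounds with values here, in a functional assay on PC-3 cells (Homo sapiens) for inhibition (on this read-out higher numbers stand for weaker inhibition and lower numbers for stronger inhibition), compound 3 gives 29200 nM, the highest of the two numbers measured so far. Compound 1 `Cc1c(C(=O)N/N=C\c2cc(F)ccc2O)oc2cccc(O)c12` gives 3170 nM in this assay, and the step of a 9.2-fold higher number from compound 1 to compound 3 (0.96 log units; beyond the scatter) marks phenyl in place of 5-fluoro-2-hydroxyphenyl. Compound 2 `Cc1c(C(=O)N/N=C\c2ccc(C(F)(F)F)cc2)oc2cccc(O)c12` reaches only a limit of this assay, namely >= 40000 nM. Compound 4 `Cc1c(C(=O)N/N=C\c2ccc(F)cc2)oc2cccc(O)c12` differs from compound 3 by fluoro in place of hydrogen on an aromatic carbon. The step that bears on this is an at least 1.3-fold lower number from compound 2 to compound 3 (0.13 log units; that floor lies within the scatter), in which a different group on an aromatic carbon gave a step within the scatter. No step beyond the scatter is therefore expected. Compound 4 is estimated at 30000 nM, with a range from 12000 nM to 60000 nM. The step so expected is a 1.0-fold higher number from compound 3 to compound 4 (0.01 log units; within the scatter).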

Compound 4, half-maximal inhibitory concentration: >= 40000 nM
Compound 4 gave a limit, no number (the forecaster's own chance of this, stated with the estimate: 25%); at least 1.3-fold (0.12 log units) between middle value and limit.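

Compound 4 reaches only a limit of this assay, not a number. A lone fluoro on the plain phenyl therefore brings no sign of stronger inhibition, with an at least 1.3-fold higher number from compound 3 to compound 4 (0.13 log units; that floor lies within the scatter), while the 5-fluoro-2-hydroxyphenyl group keeps a clear lead, with an at least 12-fold higher number from compound 1 to compound 4 (1.10 log units; beyond the scatter). The step from trifluoromethyl to fluoro cannot be read, because both compounds sit at the limit: the limit of >= 40000 nM in this assay, at which 2 of the 4 values shown sit.

Whether the hydroxy or the fluoro of compound 1 accounts for its lower number stays open. So does what an amine or a carboxylic acid on the phenyl would give.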